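This account rests on a few compounds, and the source may have more. Where it says the series, first, only, none or still open, it means among the compounds named here.

Compound 1 `CSc1ncc(C#Cc2cccc(C)c2)cn1` was tested in an assay on HEK293 cells for positive allosteric modulation of metabotropic glutamate receptor 5 (Rattus norvegicus) (a higher number here means that more compound is needed for the effect, a lower number that less compound is needed), and recorded as "not active" (no number reported), so no single number marks where it stands. A related compound 2 `CNc1ncc(C#Cc2ccc(C)cc2)cn1` gives 704000 nM in this assay. Compound 3 `COc1ncc(C#Cc2cccc(C)c2)cn1` differs from compound 1 by methoxy in place of methylsulfanyl on an aromatic carbon. Among the compounds with values here, no measured step with a number exists for this change, so its size and direction cannot be drawn from the data; only a step no larger than the scatter, or no clear potency at all, is foreseen. Compound 3 is therefore expected to give about 500000 nM in this assay, within a range of 100000 nM to 3000000 nM.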

Compound 3, half-maximal effective concentration: "not active" (no number reported)
The entry for compound 3 holds no number; there is nothing to compare the estimate with.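

Within the data shown here, compound 1 ("not active" (no number reported)) and compound 3 ("not active" (no number reported)) allow no step to be read in this assay, and no evidence bears on this result. On these data alone, whether methoxy in place of methylsulfanyl shifts potency at all remains open.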